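Opening a Ring on the Pyridine Side of a TRPV1 Antagonist

This account rests on a few compounds, and the source may have more. Where it says the series, first, only, none or still open, it means among the compounds named here.

Compound 1 `CCC1CCC(c2nc(C(F)(F)F)ccc2CNC(=O)C(C)c2ccc(NS(C)(=O)=O)c(F)c2)CC1`: 0.3 nM
Compound 2 `CC(C(=O)NCc1ccc(C(F)(F)F)nc1C1CC2CCC1C2)c1ccc(NS(C)(=O)=O)c(F)c1`: 1.5 nM
Compound 3 `CC1C=C(c2nc(C(F)(F)F)ccc2CNC(=O)C(C)c2ccc(NS(C)(=O)=O)c(F)c2)CCC1`: 0.2 nM

Three compounds share one core and differ only in the group carried on an aromatic carbon of the shared core. In an assay on CHO cells for antagonist activity at transient receptor potential cation channel subfamily V member 1 (Homo sapiens), read by FLIPR and calcium flux (a higher number here means a weaker inhibitor, a lower number a stronger inhibitor), compound 3 gives 0.2 nM, the lowest of the three numbers; its step to compound 1 is within the scatter, and only its step to compound 2 is beyond it, a 7.5-fold lower number from compound 2 to compound 3 (0.88 log units; beyond the scatter). Compound 1, with a 4-ethylcyclohexyl group, gives 0.3 nM; compound 2, with a bicyclic group, gives 1.5 nM, and a 5.0-fold higher number from compound 1 to compound 2 (0.70 log units; beyond the scatter).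

Compound 4 `CCC/C=C\c1nc(C(F)(F)F)ccc1CNC(=O)C(C)c1ccc(NS(C)(=O)=O)c(F)c1` is not yet measured. It differs from compound 3 by pent-1-en-1-yl in place of 3-methylcyclohex-1-en-1-yl on an aromatic carbon, so the ring is opened into a short chain of five carbons. Going by the values given here, none of the measured steps removes a ring; the two steps beyond the scatter only exchange one ring system for another, and both were modest. A modest weakening is therefore expected, with wide uncertainty: a 7.5-fold higher number from compound 3 to compound 4 (0.88 log units; beyond the scatter). Compound 4 is estimated at 1.5 nM, within 0.4 nM to 6 nM.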

Compound 4, inhibition constant: 2.1 nM
The estimate for compound 4 lay 1.4-fold (0.15 log units) below the measured number; the measured number falls inside the stated range.
By their numbers in this assay, from the lowest: compounds 3 and 1 (each within the scatter of the next); then compounds 2 and 4 (each within the scatter of the next).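

Opening the ring is the first change at this position, next to the ring nitrogen, that removes a ring rather than swapping one ring system for another, and it gives an 11-fold higher number from compound 3 to compound 4 (1.02 log units; beyond the scatter) in this assay, the only step in this set graded large. The double bond outside the aromatic ring stays, yet the chain also falls short of the saturated 4-ethylcyclohexyl group, with a 7.0-fold higher number from compound 1 to compound 4 (0.85 log units; beyond the scatter), while a 1.4-fold higher number from compound 2 to compound 4 (0.15 log units; within the scatter) leaves it indistinguishable from the bicyclic group. No evidence is available on why the ring matters here.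

The change removes the ring and shortens the group together, so these compounds cannot separate the two effects. Going by these compounds, whether a longer chain with the same carbon count as 3-methylcyclohex-1-en-1-yl, or a saturated pentyl chain, would behave like compound 4 remains open.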